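Ring amides on the shared core: compound 3 to compound 4

A few compounds are considered here, and "the series" means these few. Any claim that something is new, unique, unknown or untested is made for them only; others in the source may bear on it.

Compound 1 `CN1CCc2nc(C#Cc3ccccc3)sc2C1`: in an assay on HEK293 cells for negative allosteric modulation of metabotropic glutamate receptor 5 (Homo sapiens), read by FLIPR, with a stated time of 1 h (on this read-out lower numbers stand for stronger inhibition and higher numbers for weaker inhibition), compound 1 reaches only the assay limit, > 10000 nM.
Compound 2 `CCC(=O)N1CCc2nc(C#Cc3ccccc3)sc2C1`: in this assay compound 2 gives 38 nM.
Compound 3 `CC1CCCC(C(=O)N2CCc3nc(C#Cc4ccccc4)sc3C2)C1`: in this assay compound 3 reaches only the assay limit, > 10000 nM.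

Compound 3 thus stands at the limit of this assay, (the limit of > 10000 nM in this assay, at which 2 of the 3 values shown sit), and only a bound is known for it. Compound 4 `O=C(C1CCCCO1)N1CCc2nc(C#Cc3ccccc3)sc2C1` differs from it by oxan-2-yl in place of 3-methylcyclohexyl on a carbonyl carbon. Going by the values given here, two measured steps bear on the acyl group: an at least 260-fold lower number from compound 1 to compound 2 (2.42 log units; beyond the scatter) and an at least 260-fold higher number from compound 2 to compound 3 (2.42 log units; beyond the scatter), both large. Among the compounds with values here, the second is the nearer parallel: compound 4 keeps a six-membered ring on the carbonyl carbon, whereas compound 2 carries the only small acyl group and gives the only strong value. The expected step is an at least 2.0-fold lower number from compound 3 to compound 4 (0.30 log units; that floor lies within the scatter), modest. Compound 4 is estimated at 5000 nM, in the range 500 nM to 20000 nM, with a fair chance that only a limit is again reported.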

Compound 4, half-maximal inhibitory concentration: > 10000 nM
Compound 4: a limit, no number; the forecaster's own chance of this, stated with the estimate: 45%; middle value at least 2.0-fold (0.30 log units) from the limit.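

In this assay compound 4 gives only a limit, > 10000 nM. Oxan-2-yl on the carbonyl carbon, with its one hydrogen-bond acceptor, therefore does not restore the value seen with ethyl, the step being an at least 260-fold higher number from compound 2 to compound 4 (2.42 log units; beyond the scatter). The steps to compound 4 from compound 3 and from compound 1 cannot be read, as each joins two limits, so the two ring amides cannot be ranked.

Going by these compounds, whether a smaller ring such as cyclopropyl or a longer chain such as butyl on the carbonyl carbon would keep a measurable value remains open. So does how far compound 3 and compound 4 lie beyond the limit.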